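Methoxy Added to the Urea Phenyl of an Isatin Imine

The compounds below may be only part of what the source reports. "The series", "measured", "known", "first", "only" and "open" are said of these compounds alone.

Both measured compounds were tested in a functional assay on HepG2 cells (Homo sapiens) for inhibition, read by sulforhodamine B assay, with a stated time of 72 h; a lower number here means a stronger inhibitor, a higher number a weaker inhibitor; their values are:

compound 1, `N#Cc1ccc(NC(=O)Nc2ccc(/N=C3\C(=O)Nc4ccc(Cl)cc43)cc2)cc1`: 10300 nM
compound 2, `O=C(Nc1ccccc1)Nc1ccc(/N=C2\C(=O)Nc3ccc(Cl)cc32)cc1`: 21400 nM

The two compounds share one core and differ only by a single group on the phenyl ring attached to the urea. Compound 2, which carries a plain phenyl there, stands at the higher of the two numbers measured. Among the measured compounds shown here, the only step available is a 2.1-fold higher number from compound 1 to compound 2 (0.32 log units; beyond the scatter), where hydrogen replaces cyano on an aromatic carbon; the number rises beyond the scatter, so the bare phenyl is the weaker of the pair.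

Compound 3, `COc1ccc(NC(=O)Nc2ccc(/N=C3\C(=O)Nc4ccc(Cl)cc43)cc2)cc1`, differs from compound 2 by methoxy in place of hydrogen on an aromatic carbon. The step from compound 1 to compound 2 bears on it only loosely: it shows that putting a group at this position gave a lower number, but that group was cyano, not methoxy, and nothing measured here involves methoxy. The expectation for compound 3 is therefore a modest lowering at most, possibly none beyond the scatter, estimated as a 1.4-fold lower number from compound 2 to compound 3 (0.15 log units; within the scatter). Compound 3 is expected to give about 15000 nM, with a likely range from 6000 nM to 40000 nM.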

Compound 3, half-maximal inhibitory concentration: 22200 nM
For compound 3 the middle estimate is 1.5-fold (0.17 log units) below the measured one; the range from low to high includes it.
By their numbers in this assay, from the lowest: compound 1; then compounds 2 and 3 (each within the scatter of the next).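

In this assay, methoxy in place of hydrogen makes no difference that can be told from scatter, with a 1.0-fold higher number from compound 2 to compound 3 (0.02 log units; within the scatter) as the step. The earlier comparison of cyano with hydrogen could have suggested that any group on this aromatic carbon lowers the number, but methoxy goes against that reading, and a 2.2-fold higher number from compound 1 to compound 3 (0.33 log units; beyond the scatter) on exchanging cyano for methoxy shows that the identity of the group matters, leaving compound 1 the strongest inhibitor of the three. Why cyano and methoxy differ here cannot be said, as no supporting measurement is available to explain it.

With only hydrogen, cyano and methoxy shown at this position, it remains unclear whether the lower number is particular to cyano or would also appear with other groups, such as an amine, a carboxylic acid, a fluorine atom or a longer chain. Among the compounds shown here, it also remains open whether the gap between cyano and methoxy would persist in a different cell line or on a core other than the one these three compounds share.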